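Trifluoromethoxy for butyl on the aryl ring of compound 1

The source may report more compounds than this note shows. Statements on the series, on what has been measured and on what is new or still open speak of the compounds shown alone.

Measured compounds:
compound 1, `CCCCc1ccc([C@H]2C[C@@H](Nc3nc4cc[nH]c4c(=O)n3C)CN(C)C2)cc1`, 35 nM in an assay for binding affinity to histone acetyltransferase KAT2B (Homo sapiens), read by HTRF, with a stated time of 15 h; on this read-out lower numbers stand for stronger inhibition and higher numbers for weaker inhibition
compound 2, `CN1C[C@H](Nc2nc3cc[nH]c3c(=O)n2C)C[C@H](c2ccc(Cl)c(C(F)(F)F)c2)C1`, 30 nM in this assay

Compound 1 stands within the usual scatter of compound 2 in this assay, so the two numbers show no separation. Compound 3, `CN1C[C@H](Nc2nc3cc[nH]c3c(=O)n2C)C[C@H](c2ccc(OC(F)(F)F)cc2)C1`, has not yet been measured. It differs from compound 1 by trifluoromethoxy in place of butyl on an aromatic carbon. Among the compounds with values here, no measured pair isolates such a change, so the step is expected to be small, in either direction or none beyond the scatter: a 1.3-fold higher number from compound 1 to compound 3 (0.11 log units; within the scatter). Compound 3 is therefore estimated at 45 nM, with a range from 15 nM to 140 nM.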

Compound 3, half-maximal inhibitory concentration: 17 nM
Compound 3: middle estimate off by 2.6-fold (0.42 log units), on the high side, within the range that was stated.
By their numbers in this assay, from the lowest: compounds 3, 2 and 1 (each within the scatter of the next, the first and the last beyond it).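

Trifluoromethoxy in place of butyl gives a 2.1-fold lower number from compound 1 to compound 3 (0.31 log units; beyond the scatter) in this assay on this aromatic carbon, para to a large group. Within the data shown here, this is the first pair differing in one place, and it shows that a change here can move the number beyond the scatter, though only modestly. Nothing measured here accounts for the step.

The compounds shown leave open whether the oxygen or the fluorine atoms of the entering group matter, which methoxy or ethyl at this carbon could separate. From the compounds shown here alone, how an amine or a carboxylic acid would fare here also remains open.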